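The source may hold more compounds than are shown below. What is called first, only, known or untested is meant among the compounds shown, and "the series" means these compounds.

Compound 1 `Cc1ccccc1-c1nn(-c2ccc(Br)cc2)cc1CNCCN1CCN(C)CC1` carries a 4-bromophenyl group on the shared core. In an ADME assay on Huh-7 cells (Homo sapiens) for cytotoxicity (a higher number here means that more compound is tolerated, a lower number that less compound is tolerated), compound 1 gives 9600 nM. Compound 2 `CCCCCNCc1cn(-c2ccc(F)cc2F)nc1-c1ccccc1C`, with a different aryl group and a pentyl chain on the amine, gives in this assay 17000 nM. These two numbers lie within the usual scatter of each other, so neither compound can be called better tolerated than the other. Compound 3 `CCN(CC)CCCNCc1cn(-c2ccc(F)cc2F)nc1-c1ccccc1C` differs from compound 2 by diethylamino in place of ethyl on a saturated chain carbon, three bonds along the chain from an amine nitrogen. For compound 3 the result in this assay is only a limit, > 20000 nM. That value sits at the limit of > 20000 nM in this assay, at which 1 of the 3 values shown sits.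

For the measured compounds named here, the single measured step, an at least 1.1-fold higher number from compound 2 to compound 3 (0.07 log units; that floor lies within the scatter), concerns the chain and not the aryl ring, so no measured step bears directly on the change studied here. Compound 4 `Cc1ccccc1-c1nn(-c2ccc(F)cc2)cc1CNCCN1CCN(C)CC1` differs from compound 1 by fluoro in place of bromo on an aromatic carbon. With nothing in the measured steps pointing either way, no shift beyond the scatter is expected. Compound 4 is therefore estimated to give 11000 nM in this assay, between 5000 nM and 20000 nM. The expected step, a 1.1-fold higher number from compound 1 to compound 4 (0.06 log units; within the scatter), lies within the scatter.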

Compound 4, half-maximal cytotoxic concentration: > 20000 nM
Compound 4 was reported as a limit (the forecaster's own chance of this, stated with the estimate: 20%); at least 1.8-fold (0.25 log units) between middle value and limit.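

In this assay compound 4 is reported only as a limit, > 20000 nM. Replacing the 4-bromophenyl group with 4-fluorophenyl, while the rest of the molecule stays the same, gives an at least 2.0-fold higher number from compound 1 to compound 4 (0.31 log units; beyond the scatter), so a single halogen on this aromatic carbon does change how much compound the cells tolerate. The only earlier step lay in the chain and stayed within the scatter, so this is the first step shown to clear it, and its full size remains unknown with the reading at the ceiling: the limit of > 20000 nM in this assay, at which 2 of the 4 values shown sit.

From the compounds shown here alone, it remains open where chloro or methoxy at this position would fall relative to bromo and fluoro. Also open, going by these compounds, is whether the same swap would have a similar effect in a compound carrying the pentyl chain of compound 2.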